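This account rests on a few compounds, and the source may have more. Where it says the series, first, only, none or still open, it means among the compounds named here.

Working notes on the series. For the measured compounds named here, in a functional assay on HT-29 cells (Homo sapiens) for inhibition, read by MTT assay, with a stated time of 72 h (on this read-out lower numbers stand for stronger inhibition and higher numbers for weaker inhibition), compound 1 `CCCNC(=C\C(=O)/C=C/c1ccc(O)c(OC)c1)/C=C/c1ccc(O)c(OC)c1` gives 22700 nM, the only numeric value so far. Compound 2 `COc1cc(/C=C/C(=O)/C=C(/C=C/c2ccc(OC(C)=O)c(OC)c2)NCC(C)C)ccc1OC(C)=O` is reported only as a limit, > 25000 nM, in this assay. Compound 1 therefore stands as the sole quantified point, and its value lies close to that limit. Going by the values given here, compounds 1 and 2 differ in more than one place, so no measured step isolates a change on the amine chain.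

Compound 3 `CCCCNC(=C\C(=O)/C=C/c1ccc(O)c(OC)c1)/C=C/c1ccc(O)c(OC)c1` extends the chain of compound 1: methyl in place of hydrogen on a saturated chain carbon, three bonds along the chain from an amine nitrogen. This places methyl in place of hydrogen on a saturated chain carbon, three bonds along the chain from an amine nitrogen, taking propyl to butyl. Among the compounds with values here, with no measured step to scale from, the expectation in this assay is a change no larger than the usual scatter, with no favoured direction. Within the data shown here, the only anchor is compound 1 at 22700 nM. The expected 1.1-fold lower number from compound 1 to compound 3 (0.05 log units; within the scatter) is small. The estimate for compound 3 is 20000 nM, with an expected range of 10000 nM to 25000 nM.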

Compound 3, half-maximal inhibitory concentration: 19700 nM
Beside the measured number, compound 3's estimate is 1.0-fold (0.01 log units) above it; low and high end bracket the measured number.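

Taking propyl to butyl, methyl in place of hydrogen on a saturated chain carbon, three bonds along the chain from an amine nitrogen, gives a 1.2-fold lower number from compound 1 to compound 3 (0.06 log units; within the scatter) in this assay and is the first measured step at this position. The amine chain therefore takes this one added methyl without a shift in the read-out that stands clear of the scatter, and compound 3 provides a second quantified point in the series. Compound 2 remains a limit of the assay and not a number, and the two quantified compounds lie close to that limit, so little of the readable range remains for any further weakening to be sized: the limit of > 25000 nM in this assay, at which 1 of the 3 values shown sits.

A single step within the scatter leaves open what a longer chain such as hexyl, or a hydroxyl or carboxylic acid at the end of the chain, would give in this assay. Also open is what the acetate esters of compound 2 contribute on their own, since no compound shown separates them from its branched amine chain.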